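Swapping the ring on the side-chain ether of a weak inhibitor

The source may report more compounds than this note shows. Statements on the series, on what has been measured and on what is new or still open speak of the compounds shown alone.

Compound 1 `CC(C)[C@H](NC(=O)COc1cccc2ccccc12)C(=O)N[C@@H](CC(=O)O)C(=O)CSc1nc(-c2ccccc2)no1` is measured in a functional assay on Jurkat cells (Homo sapiens) for inhibition (on this read-out lower numbers stand for stronger inhibition and higher numbers for weaker inhibition), and gives 102000 nM. Compound 2 `CC(C)[C@H](NC(=O)COc1cccc2ccccc12)C(=O)N[C@@H](CC(=O)O)C(=O)COc1nncc(Cl)c1Cl` differs from it in one place and in this assay reaches only the limit of the assay, > 200000 nM, which is a boundary rather than a number (the limit of > 200000 nM in this assay, at which 1 of the 2 values shown sits). Going by the values given here, the change an at least 1.9-fold higher number from compound 1 to compound 2 (0.29 log units; that floor lies within the scatter) is therefore the only measured step here, and it cannot be set apart from the scatter.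

Compound 3 `CC(C)[C@H](NC(=O)COc1cccc2ccccc12)C(=O)N[C@@H](CC(=O)O)C(=O)COc1cncc2ccccc12` is not yet measured. It differs from compound 2 by isoquinolin-4-yl in place of 4,5-dichloropyridazin-3-yl on an oxygen on a saturated carbon. Among the compounds with values here, the one measured step, from a sulfanyl-linked ring to an ether-linked ring at this same position, touched the same end of the molecule and stayed within scatter, so it gives no direction to lean on, and compound 2 itself is known only as a limit. Compound 3 is therefore expected to land near 150000 nM in this assay, within a broad range from 30000 nM to 600000 nM, an estimated step of an at least 1.3-fold lower number from compound 2 to compound 3 (0.12 log units; that floor lies within the scatter).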

Compound 3, half-maximal inhibitory concentration: 166000 nM
Compound 3: middle estimate off by 1.1-fold (0.04 log units), on the low side; low and high end bracket the measured number.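

In this assay, going by these compounds alone, (isoquinolin-4-yl)oxy in place of (3-phenyl-1,2,4-oxadiazol-5-yl)sulfanyl gives a 1.6-fold higher number from compound 1 to compound 3 (0.21 log units; within the scatter); this is the first step at this position read between two real numbers, and it shows that this exchange of both ring and linking atom produces no change that can be told from the scatter. Isoquinolin-4-yl in place of 4,5-dichloropyridazin-3-yl on the same oxygen gives an at least 1.2-fold lower number from compound 2 to compound 3 (0.08 log units; that floor lies within the scatter), so a larger ring of two fused aromatic rings shows no readable gain over the single ring it replaces. That step has only a floor and cannot be sized further, because compound 2 is known only as a limit: the limit of > 200000 nM in this assay, at which 1 of the 3 values shown sits.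

The compounds shown leave open whether any group at this position can move the number beyond the scatter, since all three values sit at the weak end of the assay. A simple amine or a lone fluorine in place of the ring-bearing group would test whether a ring is needed here at all.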